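The source may hold more compounds than are shown below. What is called first, only, known or untested is meant among the compounds shown, and "the series" means these compounds.

In a functional assay on the whole organism (Abdomen, strain ddY) for inhibition, with Mus musculus as the target, with stated times of 30 min and 20 min (on this read-out lower numbers stand for an effect already at smaller amounts and higher numbers for an effect only at larger amounts of compound), compound 1 `CCCNc1cnn(C)c(=O)c1OCC` gives 72 mg/kg, and compound 2 `CCOc1c(N(C)C)cnn(C)c1=O` gives 86 mg/kg. Compound 3 `CCOc1ccnn(C)c1=O` is reported only as a limit, > 100 mg/kg, so it has no exact place in the series. That result is the limit of > 100 mg/kg in this assay, at which 1 of the 3 values shown sits.

The next change leads to compound 4 `Cn1ncccc1=O`, which has no ethoxy group: hydrogen in place of ethoxy on an aromatic carbon. In short, hydrogen stands in place of ethoxy on an aromatic carbon.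

Within the data shown here, no measured step changes the ethoxy group, so the evidence is indirect. Exchanging the two amino groups gives a 1.2-fold higher number from compound 1 to compound 2 (0.08 log units; within the scatter). Replacing them with hydrogen gives an at least 1.3-fold higher number from compound 1 to compound 3 (0.14 log units; that floor lies within the scatter) and an at least 1.1-fold higher number from compound 2 to compound 3 (0.06 log units; that floor lies within the scatter). These steps concern a different substituent, and the two that end at compound 3 are floors rather than exact sizes.

Given an at least 1.3-fold higher number from compound 1 to compound 3 (0.14 log units; that floor lies within the scatter), no step clearly beyond the scatter is expected in this assay, although the true size remains open. Any movement is expected to be toward higher numbers, and another limit is more likely than an exact value.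

The expected change is a step that the limit leaves unreadable from compound 3 to compound 4. For compound 4 the estimated value is 130 mg/kg, with an expected range from 70 mg/kg to 300 mg/kg.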

Compound 4, dose for half-maximal effect: 65 mg/kg
Compound 4: middle estimate off by 2.0-fold (0.30 log units), on the high side; measured number below the stated range.
By their numbers in this assay, from the lowest: compounds 4, 1 and 2 (each within the scatter of the next). At a limit, above all of these: compound 3.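

Among these compounds, this is the only measured step at the ethoxy position, and in this assay hydrogen in place of ethoxy on an aromatic carbon gives an at least 1.5-fold lower number from compound 3 to compound 4 (0.18 log units; that floor lies within the scatter). Among the compounds shown here, with hydrogen at this position, compound 4 gives 65 mg/kg, an exact value, so the ethoxy group is not required for a readable effect, and its removal does not push the number toward higher values as the earlier steps had suggested. Compound 3 stands at a limit, > 100 mg/kg, so the step has a floor for its size and a direction, but the floor alone does not carry it beyond the scatter.

The true size of this step stays open because one of its two ends is a limit: the limit of > 100 mg/kg in this assay, at which 1 of the 4 values shown sits. The compounds shown also leave open how a methoxy group, a longer alkoxy chain, a hydroxyl or an amine would read at this position, and whether hydrogen in place of ethoxy gives the same kind of step when propylamino or dimethylamino is present on the shared core.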